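Cytotoxicity in a nucleoside series: a carbamoyl to ester step

The source may report more compounds than this note shows. Statements on the series, on what has been measured and on what is new or still open speak of the compounds shown alone.

Compound 1 `COC(=O)[C@H]1O[C@@H](n2cc(C)c(=O)[nH]c2=O)C[C@@H]1N=[N+]=[N-]` gives > 847000 nM in an ADME assay on Huh-7 cells (Homo sapiens) for cytotoxicity, read by XTT assay, with a stated time of 2 days; a lower number here means that less compound is tolerated, a higher number that more compound is tolerated; this value is a limit of the assay.
Compound 2 `COC(=O)[C@@H]1CC[C@H](n2ccc(=O)[nH]c2=O)O1` gives > 1040000 nM in this assay; this value is a limit of the assay.
Compound 3 `Cc1cn([C@H]2CC=C(C(N)=O)O2)c(=O)[nH]c1=O` gives > 1050000 nM in this assay; this value is a limit of the assay.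

Within the data shown here, compound 3 thus stands at a limit and not at a number, and the same holds for every other compound measured so far (the limit of > 1040000 nM in this assay, at which 1 of the 3 values shown sits, (the limit of > 1050000 nM in this assay, at which 1 of the 3 values shown sits), (the limit of > 847000 nM in this assay, at which 1 of the 3 values shown sits)). Among the measured compounds shown here, no two measured compounds differ in one place, so no measured step is available in this assay.

Compound 4 `COC(=O)C1=CC[C@H](n2cc(C)c(=O)[nH]c2=O)O1` has not been measured. It differs from compound 3 in one place: methoxy in place of amino on a carbonyl carbon, or carbamoyl to methoxycarbonyl when cut one bond further out.

With every measured compound sitting at a limit, no step beyond the scatter is expected; the estimated step is an at least 1.0-fold lower number from compound 3 to compound 4 (0.02 log units; that floor lies within the scatter). Compound 4 is expected to give 1000000 nM in this assay, within 300000 nM to 3000000 nM, most likely reported again as a limit.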

Compound 4, half-maximal cytotoxic concentration: > 992000 nM
Compound 4: only a limit was reported (the forecaster's own chance of this, stated with the estimate: 85%); the middle value lies beyond the limit too.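

In this assay, compound 3 gives > 1050000 nM, which is a limit. Compound 4 gives > 992000 nM, also a limit, and no step can be read between these two compounds. The compounds shown leave open the concentration at which any of them turns cytotoxic, and whether carbamoyl to methoxycarbonyl shifts it.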